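This account rests on a few compounds, and the source may have more. Where it says the series, first, only, none or still open, it means among the compounds named here.

Measured compounds in an ADME assay on PBMC cells (Homo sapiens) for cytotoxicity, with a stated time of 5 days; on this read-out higher numbers stand for weaker inhibition and lower numbers for stronger inhibition:
- compound 1 `Cc1ccsc1C(=O)/C=C/c1ccc(N2CCCCC2)cc1` gives 26400 nM
- compound 2 `O=C(/C=C/c1ccc(N2CCCCC2)cc1)c1ccc(Cl)s1` gives > 100000 nM; this is a limit of the assay, not a number
- compound 3 `O=C(/C=C/c1ccc(N2CCCCC2)cc1)c1cc(Cl)sc1Cl` gives 42800 nM

Compound 1 holds the lowest of the two numbers in this assay; compound 3 is nearest, and the gap in a 1.6-fold higher number from compound 1 to compound 3 (0.21 log units; within the scatter) is within the scatter, so no order between the two can be read. Compound 2 sits at the limit of > 100000 nM in this assay, at which 1 of the 3 values shown sits.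

Compound 4 `O=C(/C=C/c1ccc(N2CCCCC2)cc1)c1ccc(Br)s1` differs from compound 1 as follows: 5-bromothiophen-2-yl in place of 3-methylthiophen-2-yl on a carbonyl carbon. The measured step that bears on this is the one to the 5-chlorothiophen-2-yl of compound 2, an at least 3.7-fold higher number from compound 1 to compound 2 (0.57 log units; beyond the scatter), a rise beyond the scatter and open-ended at the limit. The step of an at least 2.3-fold lower number from compound 2 to compound 3 (0.36 log units; beyond the scatter) shows the 2,5-dichlorothiophen-3-yl of compound 3 reading below that limit, but compound 4 follows the pattern of compound 2 and not of compound 3. A higher number for compound 4 in this assay is therefore expected, at least modest in size, with a fair chance that only a limit is returned. The expected step is a 3.0-fold higher number from compound 1 to compound 4 (0.48 log units; beyond the scatter). Compound 4 is estimated at 80000 nM, with a range from 30000 nM to 200000 nM.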

Compound 4, half-maximal inhibitory concentration: > 100000 nM
Compound 4 gave a limit, no number; the forecaster's own chance of this, stated with the estimate: 50%; middle value at least 1.2-fold (0.09 log units) from the limit.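

In this assay compound 4 returns a limit and not a number, and the 5-bromothiophen-2-yl on the carbonyl carbon reads as an at least 3.7-fold higher number from compound 1 to compound 4 (0.57 log units; beyond the scatter) and as an at least 2.3-fold higher number from compound 3 to compound 4 (0.36 log units; beyond the scatter). The high reading is therefore not tied to chloro alone, since the 5-chlorothiophen-2-yl of compound 2 and the 5-bromothiophen-2-yl of compound 4 both end at the same limit, while compound 1 and compound 3 return numbers: the limit of > 100000 nM in this assay, at which 2 of the 4 values shown sit. The step between compound 2 and compound 4 cannot be read, so no order between chloro and bromo follows.

The compounds shown leave open whether the rise goes with the halogen or with the loss of the 3-methyl group, a question that a plain thiophen-2-yl or a 5-methylthiophen-2-yl would separate. From the compounds shown here alone, how far compound 2 and compound 4 lie past the limit also stays open.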